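A Benzyl in Place of a Methyl in Compound 2

This account rests on a few compounds, and the source may have more. Where it says the series, first, only, none or still open, it means among the compounds named here.

Three compounds sharing the core of compound 1 `CCN(CC)CCCN(CCCN(CC)CC)/C(C)=N\c1ccnc2cc(Cl)ccc12` have been tested in an ADME assay on HepG2 cells (Homo sapiens) for cytotoxicity, read by MTT assay, with a stated time of 48 h; on this read-out higher numbers stand for weaker inhibition and lower numbers for stronger inhibition. Compound 1 gives 3 ug/mL and compound 3 `CCN(CC)CCN/C(C)=N\c1ccnc2cc(Cl)ccc12` gives 1.32 ug/mL. Compound 2 `C/C(=N/c1ccnc2cc(Cl)ccc12)NC1CCN(C)CC1` reaches only a limit of the assay, > 30.3 ug/mL, sitting at the limit of > 30.3 ug/mL in this assay, at which 1 of the 3 values shown sits. For the measured compounds named here, the one measured step, an at least 22-fold lower number from compound 2 to compound 3 (1.36 log units; beyond the scatter), came with 2-(diethylamino)ethyl in place of 1-methylpiperidin-4-yl on an amine nitrogen. Compound 4 `C/C(=N/c1ccnc2cc(Cl)ccc12)NC1CCN(Cc2ccccc2)CC1` differs from compound 2 by phenyl in place of hydrogen on a saturated chain carbon bound to an amine nitrogen in a ring. Going by the values given here, no measured step matches this change; the step from compound 2 to compound 3 shows only that the group on that nitrogen can move the number a great deal. Compound 4 is therefore expected to show an at least 2.0-fold lower number from compound 2 to compound 4 (0.30 log units; that floor lies within the scatter), a moderate drop, with an estimated 15 ug/mL ranging from 5 ug/mL to 30.3 ug/mL.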

Compound 4, half-maximal inhibitory concentration: 8.07 ug/mL
Beside the measured number, compound 4's estimate is 1.9-fold (0.27 log units) above it, within the range that was stated.
By their numbers in this assay, from the lowest: compound 3; then compound 1; then compound 4. At a limit, above all of these: compound 2.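

Going from methyl to benzyl on the amine nitrogen in the ring gave an at least 3.7-fold lower number from compound 2 to compound 4 (0.57 log units; beyond the scatter) and so shows that the number responds at this position even with the ring kept, which compound 3 could not show, since it replaces the whole 1-methylpiperidin-4-yl group. The size of this step is only a floor, since compound 2 holds a limit and not a number: the limit of > 30.3 ug/mL in this assay, at which 1 of the 4 values shown sits.

From the compounds shown here alone, whether a longer chain between that nitrogen and the phenyl, or an amine on the phenyl, would shift the number further remains open.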